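Lipophilicity of a bromomaleimide-indole series: ethoxy to hexyl

The compounds below may be only part of what the source reports. "The series", "measured", "known", "first", "only" and "open" are said of these compounds alone.

Compound 1: `CCOc1ccc2[nH]c(-c3ccccc3)c(C3=C(Br)C(=O)NC3=O)c2c1` — 2.77
Compound 2: `CCOc1ccc2[nH]c(-c3ccc(OC)cc3)c(C3=C(Br)C(=O)NC3=O)c2c1` — 2.77
Compound 3: `CCOc1ccc2[nH]c(-c3cccc(OC)c3)c(C3=C(Br)C(=O)NC3=O)c2c1` — 2.97

In a physicochemical assay for lipophilicity (on this read-out higher numbers stand for higher lipophilicity and lower numbers for lower lipophilicity), compound 3 gives the highest of the three numbers, yet its nearest neighbour is compound 1 at a number 0.20 log units higher from compound 1 to compound 3 (within the scatter) and its furthest is compound 2 at a number 0.20 log units higher from compound 2 to compound 3 (within the scatter), both within the scatter, so no order among the three can be claimed. The step of no change at the digits printed from compound 1 to compound 2 (within the scatter) is likewise flat. All three measured steps concern a methoxy group on the pendant phenyl ring.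

Compound 4 is `CCCCCCc1ccc2[nH]c(-c3cccc(OC)c3)c(C3=C(Br)C(=O)NC3=O)c2c1`. It differs from compound 3 by hexyl in place of ethoxy on an aromatic carbon. Within the data shown here, none of the measured steps touches this position or this kind of exchange; the methoxy steps therefore give no direct guide to its size, and the expectation rests on the structural change itself. On that basis a step upward in this assay, clearly larger than the flat methoxy steps, is expected from compound 3 to compound 4, of about a number 1.93 log units higher from compound 3 to compound 4 (beyond the scatter). Compound 4 is thus estimated at 4.9, with a range from 4 to 5.8.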

Compound 4, partition coefficient: 4.26
Compound 4: middle estimate off by 0.64 log units, on the high side, within the range that was stated.
By their numbers in this assay, from the lowest: compounds 1, 2 and 3 (each within the scatter of the next); then compound 4.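

In this assay, among these compounds, the aromatic carbon that carries ethoxy in compound 3 is the first place where a change gives a step beyond the scatter: a number 1.29 log units higher from compound 3 to compound 4 (beyond the scatter). The earlier steps shown here, all on the pendant phenyl ring, stayed within the scatter, so this position, meta and para to a fused ring, behaves differently from those exchanges. Ethoxy holds an oxygen and hexyl holds only carbon. This single step changes both chain length and atom type, and it cannot separate the two, while no further data bear on the cause of the step.

The compounds shown leave open how a hexyloxy group, which would keep the oxygen, or a shorter butyl chain would compare at this carbon. They also leave open whether an amine there would move the number in the opposite direction.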